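The source may hold more compounds than are shown below. What is called first, only, known or untested is meant among the compounds shown, and "the series" means these compounds.

Compound 1, `O=C(NC1CCN(Cc2ccc(C(F)(F)F)cc2)CC1)c1cccc2ccccc12`: in an assay on isolated protein for displacement of a labelled ligand from D(4) dopamine receptor (Homo sapiens) (a lower number here means a stronger inhibitor, a higher number a weaker inhibitor), compound 1 gives 96 nM.
Compound 2, `COc1cccc(CN2CCC(NC(=O)c3cccc4ccccc34)CC2)c1`: in this assay compound 2 gives 168 nM.
Compound 3, `O=C(NC1CCN(Cc2ccc(C(F)(F)F)cc2)CC1)c1ccc2ccccc2c1`: in this assay compound 3 gives 84 nM.

Compounds 1 and 2 differ in one place, (3-methoxyphenyl in place of 4-(trifluoromethyl)phenyl on a saturated chain carbon bound to an amine nitrogen in a ring), and in this assay the move is a 1.8-fold higher number from compound 1 to compound 2 (0.24 log units; within the scatter). Compounds 1 and 3 share all their atoms but join them differently, (naphthalen-2-yl in place of naphthalen-1-yl on a carbonyl carbon), and that rearrangement gives a 1.1-fold lower number from compound 1 to compound 3 (0.06 log units; within the scatter). Within the data shown here, compound 4, `COc1cccc(CN2CCC(NC(=O)c3ccc4ccccc4c3)CC2)c1`, is not yet measured; it is related to compound 3 by 3-methoxyphenyl in place of 4-(trifluoromethyl)phenyl on a saturated chain carbon bound to an amine nitrogen in a ring, which is the same change as the one from compound 1 to compound 2, made on the core of compound 3 instead. Among the measured compounds shown here, since the one earlier instance of this change produced a 1.8-fold higher number from compound 1 to compound 2 (0.24 log units; within the scatter), a step of similar size is expected here, namely a 1.8-fold higher number from compound 3 to compound 4 (0.25 log units; within the scatter), resting on that single pair alone. The estimate for compound 4 in this assay is therefore 150 nM, expected to lie between 70 nM and 330 nM.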

Compound 4, inhibition constant: 16 nM
Compound 4: the middle estimate sits 9.4-fold (0.97 log units) above what was measured; the whole stated range lies above it.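

In this assay, putting 3-methoxyphenyl in place of 4-(trifluoromethyl)phenyl on the core of compound 3 gives a 5.3-fold lower number from compound 3 to compound 4 (0.72 log units; beyond the scatter), which is beyond the scatter. The size and direction of this change therefore do not carry over from one core to the other, even though the two cores differ only in naphthalen-2-yl in place of naphthalen-1-yl on a carbonyl carbon: the same change on two cores in this assay, a 1.8-fold higher number (0.24 log units; within the scatter) from compound 1 to compound 2 and a 5.3-fold lower number (0.72 log units; beyond the scatter) from compound 3 to compound 4, 9.2-fold (0.96 log units) apart, beyond the scatter of two such steps With a single pair on each core, this shows that the outcome of the change depends on the core in these four compounds, but it does not show why, nor how the change would behave on any further core.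

Going by these compounds, it remains open whether the lower number of compound 4 is specific to 3-methoxyphenyl or would also appear with 4-methoxyphenyl or 3-chlorophenyl at the same place. On these data alone, it is equally open whether a quinolinyl group on the carbonyl carbon would follow the naphthalen-1-yl core, the naphthalen-2-yl core or neither.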